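Methylsulfanyl in place of tert-butylamino on a shared core

The source may hold more compounds than are shown below. What is called first, only, known or untested is meant among the compounds shown, and "the series" means these compounds.

Measured compounds:
- compound 2 `NC(N)=NC(=O)c1nc(Cl)c(Nc2cnc3ccccc3c2)nc1N`: 28%
- compound 3 `NC(N)=NC(=O)c1nc(Cl)c(Nc2ccc3ncccc3c2)nc1N`: 41%

Compound 1 `CC(C)(C)Nc1nc(N)c(C(=O)N=C(N)N)nc1Cl` gives "not determined" (no result reported) in an assay for inhibition of acid-sensing ion channel 3 (Homo sapiens), read by patch clamp, tested at 1 uM; on this read-out higher numbers stand for more inhibition at the one concentration tested (going by the name of the read-out) and lower numbers for less inhibition; for it, no single number is available, so it stands nowhere on the scale that the other compounds define. Compound 2 gives 28% in this assay, and compound 3 gives 41% in this assay; both share the core of compound 1 but carry a different substituent at the same place. Compound 4 `CSc1nc(N)c(C(=O)N=C(N)N)nc1Cl` differs from compound 1 by the change (methylsulfanyl in place of (tert-butyl)amino on an aromatic carbon). Among the measured compounds shown here, because no step between measured compounds is at hand, the direction and size of this step cannot be read from the data; the two values for compound 2 and compound 3 only show where related compounds fall. Given that, compound 4 is expected to give an inhibition near 20% in this assay, with a likely range of 0% to 45%.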

Compound 4, a percentage reported as inhibition, at one concentration (the size of the read-out at that concentration, not a potency): 12%
Beside the measured number, compound 4's estimate is 8 percentage points above it, and the stated range covers the measured number.
By their numbers in this assay, from the lowest: compound 4; then compound 2; then compound 3.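

No step can be read between compound 1 and compound 4: in this assay compound 1 gives "not determined" (no result reported) while compound 4 gives 12%. The compounds shown leave open how far methylsulfanyl in place of (tert-butyl)amino changes inhibition on the shared core. No further evidence bears on this result.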